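A few compounds are considered here, and "the series" means these few. Any claim that something is new, unique, unknown or untested is made for them only; others in the source may bear on it.

Among the compounds with values here, compound 1 `Cc1cc2[nH]nc(N)c2c(=O)[nH]1` holds the lower of the two numbers measured so far, though within the scatter of the other: in an assay on isolated protein for inhibition of ribosomal protein S6 kinase alpha-5 (Homo sapiens), read by mobility shift assay, tested at 30 uM (a lower number here means less inhibition, a higher number more inhibition at the concentration tested (going by the name of the read-out)), compound 1 gives 56%. Compound 2 `Nc1n[nH]c2cc(-c3cccs3)[nH]c(=O)c12` gives 63% in this assay, and the step of a number 7 percentage points higher from compound 1 to compound 2 (within the scatter) is within the scatter. Compound 3 `Nc1n[nH]c2cc(CC3CCNCC3)[nH]c(=O)c12` differs from compound 1 by piperidin-4-yl in place of hydrogen on a saturated chain carbon bound to an aromatic carbon. Within the data shown here, the only measured step, from compound 1 to compound 2, also alters the methyl of compound 1 and was small. A step of a number 2 percentage points higher from compound 1 to compound 3 (within the scatter) is therefore expected, none beyond the scatter. In this assay compound 3 is estimated at 58%, ranging from 35% to 80%.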

Compound 3, a percentage reported as inhibition, at one concentration (the size of the read-out at that concentration, not a potency): 62%
Compound 3: middle estimate off by 4 percentage points, on the low side, and the stated range covers the measured number.
By their numbers in this assay, from the lowest: compounds 1, 3 and 2 (each within the scatter of the next).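

Placing piperidin-4-yl in place of hydrogen on a saturated chain carbon bound to an aromatic carbon gives a number 6 percentage points higher from compound 1 to compound 3 (within the scatter) in this assay. So this carbon can carry a whole six-membered non-aromatic ring, not just hydrogen, with no step beyond the scatter. Nothing available explains this result. Still open, on these data alone, is whether the ring nitrogen matters, which a cyclohexyl group in place of piperidin-4-yl would test. A carboxylic acid on this carbon might also give a step beyond the scatter.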